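Shortening the Alkoxy Chain on a Weak Lipoxygenase Inhibitor

The source may hold more compounds than are shown below. What is called first, only, known or untested is meant among the compounds shown, and "the series" means these compounds.

Of the compounds shown here, three sharing one core have been measured in a functional assay for inhibition of Polyunsaturated fatty acid 5-lipoxygenase (Homo sapiens); a lower number here means a stronger inhibitor, a higher number a weaker inhibitor. Compound 1 `CCCOc1cc(C)c2c(c1C)CC(C(C)C(=O)NCc1cccs1)CC2` gives 8000 nM, the highest of the three numbers. Compound 2 `CCCOc1cc(C)c2c(c1C)CC(C(C)C(=O)Nc1ccccn1)CC2` gives 900 nM, and compound 3 `CCCOc1cc(C)c2c(c1C)CC(C(C)C(=O)Nc1nccs1)CC2` gives 800 nM. The steps from compound 1 to these two are an 8.9-fold lower number from compound 1 to compound 2 (0.95 log units; beyond the scatter) and a 10-fold lower number from compound 1 to compound 3 (1.00 log units; beyond the scatter), while between compound 2 and compound 3 the step is a 1.1-fold lower number from compound 2 to compound 3 (0.05 log units; within the scatter). All of these changes concern the group on the amide nitrogen; none touches the alkoxy chain on the aromatic ring.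

Compound 4 `COc1cc(C)c2c(c1C)CC(C(C)C(=O)NCc1cccs1)CC2` differs from compound 1 in exactly that untouched place: hydrogen in place of ethyl on a saturated chain carbon bound to an oxygen on an aromatic ring. The amide portion of compound 1 is kept unchanged. For the measured compounds named here, no measured step therefore bears directly on this change, and the measured steps give no guidance on its direction.

Without a comparable step, the expected outcome for compound 4 in this assay is a change that stays within the scatter, a 1.3-fold higher number from compound 1 to compound 4 (0.10 log units; within the scatter), so compound 4 is estimated at 10000 nM, with a range from 3000 nM to 30000 nM.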

Compound 4, half-maximal inhibitory concentration: 8000 nM
Beside the measured number, compound 4's estimate is 1.3-fold (0.10 log units) above it, within the range that was stated.
By their numbers in this assay, from the lowest: compounds 3 and 2 (each within the scatter of the next); then compounds 1 and 4 (each within the scatter of the next).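

Shortening propoxy to methoxy gives no change at the digits printed from compound 1 to compound 4 (within the scatter) in this assay, so with the (thiophen-2-yl)methyl group on the amide nitrogen, removing the ethyl portion of the chain leaves no readable mark on the number. For the compounds shown here, this is the first look at the alkoxy chain: the earlier compounds varied only the amide nitrogen group, where a swap could produce a clear shift such as a 10-fold lower number from compound 1 to compound 3 (1.00 log units; beyond the scatter), whereas this one change to the chain produces no such shift. No supporting measurement is available to say why the number stays where it is.

On these data alone, whether the same shortening would be equally silent with the pyridin-2-yl group of compound 2 or the 1,3-thiazol-2-yl group of compound 3 remains open, since a chain change could read differently on an amide group that gives a lower number. Also open, as far as these compounds go, is what a longer chain such as butoxy, or an amine or a carboxylic acid carried on the chain, would do at this place on the shared core.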